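Fluoro for methyl on the outer phenyl ring

A few compounds are considered here, and "the series" means these few. Any claim that something is new, unique, unknown or untested is made for them only; others in the source may bear on it.

Measured compounds:
Compound 1 `Cc1ccc(-c2c(C(OC(C)(C)C)C(=O)O)c(C)nc3cc(-c4ccccc4)nn23)cc1`: 77000 nM
Compound 2 `Cc1nc2cc(-c3cccc(-c4ccccc4)c3)nn2c(-c2cc(F)c3c(c2C)CCCO3)c1[C@H](OC(C)(C)C)C(=O)O`: 6590 nM
Compound 3 `Cc1ccccc1-c1cccc(-c2cc3nc(C)c([C@H](OC(C)(C)C)C(=O)O)c(-c4cc(F)c5c(c4C)CCCO5)n3n2)c1`: 28200 nM

In an ADME assay on MT2 cells (Homo sapiens) for cytotoxicity, read by XTT assay, with a stated time of 4 days (a lower number here means that less compound is tolerated, a higher number that more compound is tolerated), compound 3 gives 28200 nM, the second highest of the three numbers. Its nearest neighbour is compound 1 at 77000 nM, and furthest away is compound 2 at 6590 nM. Among the compounds with values here, the one measured step, a 4.3-fold higher number from compound 2 to compound 3 (0.63 log units; beyond the scatter), brought a methyl onto an aromatic carbon and raised the number beyond the scatter.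

Compound 4 `Cc1nc2cc(-c3cccc(-c4ccccc4F)c3)nn2c(-c2cc(F)c3c(c2C)CCCO3)c1[C@H](OC(C)(C)C)C(=O)O` is not yet measured. It differs from compound 3 by fluoro in place of methyl on an aromatic carbon; cut one bond further out, the change reads 2-methylphenyl to 2-fluorophenyl. Within the data shown here, no measured pair carries a fluoro at this position, so the only bearing step is a 4.3-fold higher number from compound 2 to compound 3 (0.63 log units; beyond the scatter), which shows that the ring without the methyl sits lower. Fluoro is a single heavy atom, as is methyl, so a modest lowering or no change beyond the scatter seems most likely. Compound 4 is therefore expected to give 15000 nM (range 5000 nM to 45000 nM), which would mean an expected step of a 1.9-fold lower number from compound 3 to compound 4 (0.27 log units; within the scatter).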

Compound 4, half-maximal cytotoxic concentration: 19100 nM
For compound 4 the middle estimate is 1.3-fold (0.10 log units) below the measured one; low and high end bracket the measured number.
By their numbers in this assay, from the lowest: compound 2; then compounds 4 and 3 (each within the scatter of the next); then compound 1.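

In this assay, the methyl and fluoro on this aromatic carbon cannot be told apart, as a 1.5-fold lower number from compound 3 to compound 4 (0.17 log units; within the scatter) shows. The rise seen earlier is therefore not confined to methyl: fluoro in place of hydrogen also gives a change beyond the scatter, a 2.9-fold higher number from compound 2 to compound 4 (0.46 log units; beyond the scatter), so two different single-atom-sized groups at this place both separate their compounds from compound 2. Nothing available explains why either group has this effect.

The compounds shown leave open whether a larger group at this place, such as methoxy or trifluoromethyl, would move the number further than methyl or fluoro do. They also leave open whether an amine, which carries hydrogen-bond donors unlike either group here, would follow the same course.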